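Swapping the aromatic arm for a benzamidomethyl chain

The source may hold more compounds than are shown below. What is called first, only, known or untested is meant among the compounds shown, and "the series" means these compounds.

For the measured compounds named here, compound 1 `c1ccc(-c2nnc(SCCCN3CCN(c4nc5ccccc5o4)CC3)o2)cc1` and compound 2 `COc1ccc(-c2nnc(SCCCN3CCN(c4nc5ccccc5s4)CC3)o2)cc1` are the two measured members of this set. In a functional assay on HeLa cells (Homo sapiens) for inhibition, read by MTT assay, with a stated time of 72 h (on this read-out lower numbers stand for stronger inhibition and higher numbers for weaker inhibition), compound 1 gives 67000 nM, while in this assay compound 2 gives 165000 nM, the highest of the two numbers, and the gap to compound 1 lies beyond the scatter. Compound 3 `O=C(NCc1nnc(SCCCN2CCN(c3nc4ccccc4s3)CC2)o1)c1ccccc1` is the unmeasured member. It differs from compound 2 by benzamidomethyl in place of 4-methoxyphenyl on an aromatic carbon. Going by the values given here, no step between measured compounds that changes one place is available to guide this substitution. Compound 3 is expected to stay weak, with an estimated step of a 1.1-fold lower number from compound 2 to compound 3 (0.04 log units; within the scatter) that need not exceed the scatter. The estimate for compound 3 is 150000 nM, within 50000 nM to 450000 nM.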

Compound 3, half-maximal inhibitory concentration: 78100 nM
For compound 3 the middle estimate is 1.9-fold (0.28 log units) above the measured one, within the range that was stated.
By their numbers in this assay, from the lowest: compounds 1 and 3 (each within the scatter of the next); then compound 2.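

In this assay, for the compounds shown here, the swap of 4-methoxyphenyl for benzamidomethyl gives a 2.1-fold lower number from compound 2 to compound 3 (0.32 log units; beyond the scatter) and so gives the first single-place reading at this position. The longer chain, with its amide hydrogen, is accepted here without a loss, although the gain is modest and compound 3 still gives 78100 nM as a high number. Nothing measured here explains the shift. The compounds shown leave open whether a methyl group, an amine or a carboxylic acid at this position would move the number further, and whether benzamidomethyl acts alike on the core of compound 1.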